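A few compounds are considered here, and "the series" means these few. Any claim that something is new, unique, unknown or untested is made for them only; others in the source may bear on it.

Measured so far in a functional assay on MDA-MB-231 cells (Homo sapiens) for antiproliferative activity, read by CCK-8 assay, with a stated time of 72 h; on this read-out higher numbers stand for weaker inhibition and lower numbers for stronger inhibition:
- compound 1, `CC1=NN(c2ccc(C)cc2)C(=O)C12C=CC(=O)C=C2c1ccc(C)cc1`: 5110 nM
- compound 2, `CC1=NN(c2ccc(Br)cc2)C(=O)C12C=CC(=O)C=C2c1ccc(C)cc1`: 15900 nM

Compound 2 holds the higher of the two numbers. For the measured compounds named here, it is separated from compound 1 by the only measured step in the set, a 3.1-fold higher number from compound 1 to compound 2 (0.49 log units; beyond the scatter), which corresponds to bromo in place of methyl on an aromatic carbon; the step is modest but lies beyond the scatter.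

Compound 3, `CC1=NN(c2ccc(Cl)cc2)C(=O)C12C=CC(=O)C=C2c1ccc(C)cc1`, is not yet measured. It differs from compound 2 by chloro in place of bromo on an aromatic carbon. Going by the values given here, no measured step covers an exchange of one halogen for another; the one step available, a 3.1-fold higher number from compound 1 to compound 2 (0.49 log units; beyond the scatter), concerns a different exchange at the same kind of site and is the sole guide to how much this part of the molecule moves the read-out at all. On that basis the step from compound 2 to compound 3 is expected to stay within the scatter, with any movement more likely toward a slightly lower number, a 1.4-fold lower number from compound 2 to compound 3 (0.16 log units; within the scatter). Compound 3 is therefore expected to give about 11000 nM in this assay, with a range from 5000 nM to 25000 nM.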

Compound 3, half-maximal inhibitory concentration: 14300 nM
Compound 3: the middle estimate sits 1.3-fold (0.11 log units) below what was measured; measured number inside the range.
By their numbers in this assay, from the lowest: compound 1; then compounds 3 and 2 (each within the scatter of the next).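

In this assay, for the compounds shown here, going from 4-bromophenyl to 4-chlorophenyl gives a 1.1-fold lower number from compound 2 to compound 3 (0.05 log units; within the scatter) and so does not separate the two halogens at this site, para to a large group, which no earlier pair could show. The second halogen also repeats the direction of the earlier exchange: chloro in place of methyl gives a 2.8-fold higher number from compound 1 to compound 3 (0.45 log units; beyond the scatter) and bromo in place of methyl gave a 3.1-fold higher number from compound 1 to compound 2 (0.49 log units; beyond the scatter), so the gap from methyl is not confined to bromo. Across these three compounds, the read-out at this site separates methyl from the halogens but not one halogen from the other, and nothing available bears on the reason for this.

Going by these compounds, it remains open whether a methoxy group, an amine or a carboxylic acid at this site would give a number on the side of compound 1 or on the side of the halogen compounds. Also open, on these data alone, is how far the read-out depends on the methyl-bearing aromatic ring on the other side of the core, which is the same in all three compounds, and whether a fluoro group there or at the halogen site would move it.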